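This account rests on a few compounds, and the source may have more. Where it says the series, first, only, none or still open, it means among the compounds named here.

Working notes on the step from compound 2 to compound 4. In an ADME assay on L6 cells (Rattus norvegicus) for cytotoxicity (a higher number here means a weaker inhibitor, a lower number a stronger inhibitor), compound 2 (`O=C(CN1CCCC1)OC1CC2(N3CCCC3)CC(c3ccccc3)C1C(c1ccccc1)C2`) gives 42900 nM. Compound 1 (`CN(C)C12CC(OC(=O)CN3CCCC3)C(C(c3ccccc3)C1)C(c1ccccc1)C2`) gives 32700 nM, and the two stand level: the change is a 1.3-fold higher number from compound 1 to compound 2 (0.12 log units; within the scatter). Compound 3 (`O=C(CN1CCCC1)OC1CC2(N3CCCCC3)CC(c3ccccc3)C1C(c1ccccc1)C2`) gives 16400 nM; 52000 nM (2 entries), and the value of compound 2 falls inside the span of those entries. That span, set by the several entries of compound 3 in this assay, 16400 nM; 52000 nM (2 entries), shows how loosely a single number in this assay is fixed in this series.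

Compound 4 (`O=C(CN1CCCCC1)OC1CC2(N3CCCC3)CC(c3ccccc3)C1C(c1ccccc1)C2`) carries piperidin-1-yl in place of pyrrolidin-1-yl on a saturated chain carbon bound to a carbonyl carbon. Among the compounds with values here, no measured step covers that place. Within the data shown here, the only single-place step in hand, from compound 1 to compound 2, sits on a saturated ring carbon, has pyrrolidin-1-yl in place of dimethylamino, and stayed within the scatter. Among the measured compounds shown here, with that as the sole guide, no shift beyond the scatter and no particular direction is expected in this assay. The expected change is a 1.1-fold lower number from compound 2 to compound 4 (0.03 log units; within the scatter). For compound 4 the estimated value is 40000 nM, with an expected range of 16000 nM to 95000 nM.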

Compound 4, half-maximal inhibitory concentration: 14200 nM
For compound 4 the middle estimate is 2.8-fold (0.45 log units) above the measured one; the whole stated range lies above it.
By their numbers in this assay, from the lowest: compound 4; then compounds 1 and 2 (each within the scatter of the next).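

Within the data shown here, at the saturated chain carbon bound to a carbonyl carbon, piperidin-1-yl in place of pyrrolidin-1-yl gives a 3.0-fold lower number from compound 2 to compound 4 (0.48 log units; beyond the scatter), the only single-place step so far to lie beyond the scatter. Among these compounds, the earlier step, a 1.3-fold higher number from compound 1 to compound 2 (0.12 log units; within the scatter), concerned a different group on a saturated ring carbon, so this is the first indication that this assay can respond to a one-place change on this core, here toward a stronger inhibitor. The shift is still modest and rests on a single comparison, and it needs cautious reading since one number in this assay is only loosely fixed in this series: the several entries of compound 3 in this assay, 16400 nM; 52000 nM (2 entries).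

On these data alone, it remains open whether the lower number follows from piperidin-1-yl specifically or would extend to other rings at this chain carbon, such as morpholin-4-yl or azepan-1-yl. A longer chain between the carbonyl and the ring is equally unresolved, and repeat entries for compound 2 and compound 4 would show how firmly this step holds.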